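Swapping Amino for Diethylamino on the Shared Core

The source may hold more compounds than are shown below. What is called first, only, known or untested is meant among the compounds shown, and "the series" means these compounds.

Of the compounds shown here, two have been measured in a functional assay on A549 cells (Homo sapiens) for inhibition; on this read-out higher numbers stand for weaker inhibition and lower numbers for stronger inhibition. Compound 1 `COc1ccc(/C=C/c2ccc3ccccc3c2)cc1F` gives only a limit, > 5000 nM. Within the data shown here, compound 2 `COc1ccc(/C=C/c2ccc3ccccc3c2)cc1N` gives 1820 nM, the only actual number available so far. Among the measured compounds shown here, the single measured step, with amino in place of fluoro on the same aromatic carbon, is an at least 2.7-fold lower number from compound 1 to compound 2 (0.43 log units; beyond the scatter). That step shows that inhibition responds to the group at this carbon, but it says nothing directly about a larger amine.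

Compound 3 `CCN(CC)c1cc(/C=C/c2ccc3ccccc3c2)ccc1OC` changes that same carbon again, with diethylamino in place of amino (diethylamino in place of amino on an aromatic carbon). For the measured compounds named here, with only the step to compound 2 an at least 2.7-fold lower number from compound 1 to compound 2 (0.43 log units; beyond the scatter) as a guide, the size of the next step is uncertain. A modest loss of inhibition in this assay is expected, which means a higher number, although no change beyond the scatter remains possible. The estimated step is a 1.9-fold higher number from compound 2 to compound 3 (0.28 log units; within the scatter). Compound 3 could also be reported only at the limit of > 5000 nM in this assay, at which 1 of the 2 values shown sits. For compound 3 the expected value is 3500 nM, within an estimated range of 1300 nM to 9000 nM.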

Compound 3, half-maximal inhibitory concentration: > 5000 nM
Compound 3: no number, only a limit (the forecaster's own chance of this, stated with the estimate: 40%); at least 1.4-fold (0.15 log units) between middle value and limit.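

Moving from amino to diethylamino in this assay gives an at least 2.7-fold higher number from compound 2 to compound 3 (0.43 log units; beyond the scatter), so the gain that came with amino at this aromatic carbon, an at least 2.7-fold lower number from compound 1 to compound 2 (0.43 log units; beyond the scatter), does not carry over to this larger amine. Compound 2 carries a hydrogen-bond donor on this carbon and compound 3 carries none, but the two groups also differ in size, and this one step cannot separate those two differences. Compound 3 gives only a limit, so the step from amino shows a minimum size and no more, and of the three groups only amino has so far given an actual number: the limit of > 5000 nM in this assay, at which 2 of the 3 values shown sit.

The step between compound 1 and compound 3 cannot be read, as both values are limits. Going by these compounds, it remains open whether a smaller amine such as methylamino or dimethylamino would keep the inhibition seen with amino, and whether a hydroxyl group, which also carries a hydrogen-bond donor, would do the same at this carbon.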